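Dropping One Methyl from the Imidazole of Compound 2

This account rests on a few compounds, and the source may have more. Where it says the series, first, only, none or still open, it means among the compounds named here.

Measured compounds:
compound 1 `CCC(CC)(c1nnc[nH]1)c1ccc(-c2ccc3cc(F)cc(F)c3c2)[nH]c1=O` gives 89 nM in an assay on CHO cells for displacement of a labelled ligand from prostaglandin E2 receptor EP3 subtype (Homo sapiens), read by radioligand binding; on this read-out higher numbers stand for weaker inhibition and lower numbers for stronger inhibition
compound 2 `Cc1nc(C(c2ccc(-c3ccc4cccc(F)c4c3)[nH]c2=O)C(C)C)[nH]c1C` gives 7 nM in this assay
compound 3 `CCn1ncc2c(F)cc(-c3ccc(C(CC)(CC)c4ncn(C)n4)c(=O)[nH]3)cc21` gives 39 nM in this assay

Of these three, compound 2 stands lowest in this assay; compound 3 lies above it beyond the scatter, and compound 1 further still. Compound 4 `Cc1c[nH]c(C(c2ccc(-c3ccc4cccc(F)c4c3)[nH]c2=O)C(C)C)n1` is not yet measured. For the measured compounds named here, its only difference from compound 2 is hydrogen in place of methyl on an aromatic carbon, so that 4,5-dimethyl-1H-imidazol-2-yl becomes 4-methyl-1H-imidazol-2-yl. Going by the values given here, no measured pair shows this difference, so the expected step in this assay is small: either toward a higher number or none beyond the scatter. Compound 4 is therefore estimated at 12 nM, in a range from 5 nM to 30 nM, meaning an expected step of a 1.7-fold higher number from compound 2 to compound 4 (0.23 log units; within the scatter).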

Compound 4, inhibition constant: 12 nM
Beside the measured number, compound 4's estimate shows no gap at the digits printed; low and high end bracket the measured number.
By their numbers in this assay, from the lowest: compounds 2 and 4 (each within the scatter of the next); then compound 3; then compound 1.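

In this assay, for the compounds shown here, hydrogen in place of methyl on this aromatic carbon gives a 1.7-fold higher number from compound 2 to compound 4 (0.23 log units; within the scatter), the first comparison that differs only at this position. This methyl can therefore be lost without a step beyond the scatter, so the number does not depend measurably on it. Nothing available explains this result.

On these data alone, it remains open whether the remaining methyl can also give way to hydrogen. As far as these compounds go, it is also open how a larger group on this carbon, such as ethyl or trifluoromethyl, would read.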